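This account rests on a few compounds, and the source may have more. Where it says the series, first, only, none or still open, it means among the compounds named here.

Among the compounds with values here, in a functional assay on HeLa cells (Homo sapiens) for cytotoxicity, read by WST assay, with a stated time of 48 h (on this read-out higher numbers stand for weaker inhibition and lower numbers for stronger inhibition), compound 2 `COc1cc(C(c2ccc(O)c(OC)c2)[C@H](CC(C)C)C(C)C)ccc1O` gives 8200 nM, the only number so far. Compound 1 `COc1cc(C(c2ccc(O)c(OC)c2)[C@@H](C)[C@H](C)CO)ccc1O` stands at a limit, > 100000 nM. Compound 3 `COc1cc(C(c2ccc(O)c(OC)c2)[C@H](C)[C@H](C)CF)ccc1O` follows from compound 2 by 2-(fluoromethyl)-1-methylpropyl in place of 1-isopropyl-3-methylbutyl on a saturated chain carbon bound to two aromatic carbons. Within the data shown here, the one measured step bearing on this is large: an at least 12-fold lower number from compound 1 to compound 2 (1.08 log units; beyond the scatter), which brought in the 1-isopropyl-3-methylbutyl in place of 2-(hydroxymethyl)-1-methylpropyl. Compound 3 gives up that group again, so part of this step is expected to be lost, with a higher number in this assay. The expected change is a 3.7-fold higher number from compound 2 to compound 3 (0.56 log units; beyond the scatter). For compound 3 the estimate is 30000 nM, with an expected range of 12000 nM to 90000 nM.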

Compound 3, half-maximal inhibitory concentration: 75000 nM
Compound 3: the middle estimate sits 2.5-fold (0.40 log units) below what was measured; measured number inside the range.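

Replacing 1-isopropyl-3-methylbutyl with 2-(fluoromethyl)-1-methylpropyl on a saturated chain carbon bound to two aromatic carbons gives a 9.1-fold higher number from compound 2 to compound 3 (0.96 log units; beyond the scatter) in this assay, so among the compounds shown, only 1-isopropyl-3-methylbutyl gives a clearly lower number. Fluorine in place of the hydroxyl group gives an at least 1.3-fold lower number from compound 1 to compound 3 (0.12 log units; that floor lies within the scatter), so no order between these two compounds can be stated. Compound 1 stands at a limit, not a number: the limit of > 100000 nM in this assay, at which 1 of the 3 values shown sits.

Still open, going by these compounds, is whether the chain itself or the loss of its fluorine-bearing or hydroxyl-bearing end matters more. An amine at that chain end, or a longer chain with only carbon, would help separate the two.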